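Swapping the aryl amide in a cyclopropane-linked series

This account rests on a few compounds, and the source may have more. Where it says the series, first, only, none or still open, it means among the compounds named here.

Of the compounds shown here, three sharing one core have been measured in a functional assay on A549 cells (Homo sapiens) for inhibition, read by CCK-8 assay, with a stated time of 72 h, tested at 1 uM; a lower number here means less inhibition of growth, a higher number more inhibition of growth at the concentration tested. Compound 1 `CN(C)C(=O)c1cc2cnc(Nc3ccc(NC(=O)C4(C(=O)Nc5ccccc5F)CC4)cc3)nc2n1C1CCCC1` gives 79.1% in this assay. Compound 2 `CN(C)C(=O)c1cc2cnc(Nc3ccc(NC(=O)C4(C(=O)Nc5ccc(Cl)c(C(F)(F)F)c5)CC4)cc3)nc2n1C1CCCC1` gives 1.1%. Compound 3 `CN(C)C(=O)c1cc2cnc(Nc3ccc(NC(=O)C4(C(=O)Nc5cccc(Cl)c5)CC4)cc3)nc2n1C1CCCC1` gives 8.3%, which places it second highest of the three, close to compound 2 and far from compound 1. Compound 4 `COC(=O)c1ccc(NC(=O)C2(C(=O)Nc3ccc(Nc4ncc5cc(C(=O)N(C)C)n(C6CCCC6)c5n4)cc3)CC2)cc1` has not yet been measured; it differs from compound 3 in one place, with the change (4-(methoxycarbonyl)phenyl in place of 3-chlorophenyl on an amide-type nitrogen).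

The measured steps speak to this change only indirectly. Replacing the 2-fluorophenyl of compound 1 gave a number 78 percentage points lower from compound 1 to compound 2 (beyond the scatter) and a number 70.8 percentage points lower from compound 1 to compound 3 (beyond the scatter), both large drops, while moving between the two other phenyl groups gave a number 7.2 percentage points higher from compound 2 to compound 3 (within the scatter), which is within the scatter. Going by the values given here, no measured step contains a 4-(methoxycarbonyl)phenyl, so the outcome for compound 4 rests on the observation that two different substituted phenyl groups both sat low.

Compound 4 is therefore expected to stay low in this assay, with a step of about a number 6.7 percentage points higher from compound 3 to compound 4 (within the scatter) and an estimate of 15%, between 0% and 55%.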

Compound 4, percent growth inhibition at one concentration: 77.1%
Beside the measured number, compound 4's estimate is 62.1 percentage points below it; the whole stated range lies below it.
By their numbers in this assay, from the lowest: compounds 2 and 3 (each within the scatter of the next); then compounds 4 and 1 (each within the scatter of the next).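

Going by these compounds alone, the readings in this assay show that 2-fluorophenyl is not the only group on this amide-type nitrogen that keeps growth inhibition high. The change to 4-(methoxycarbonyl)phenyl gives a number 68.8 percentage points higher from compound 3 to compound 4 (beyond the scatter) and also a number 76 percentage points higher from compound 2 to compound 4 (beyond the scatter) while the change from 2-fluorophenyl gives a number 2 percentage points lower from compound 1 to compound 4 (within the scatter) so replacing 2-fluorophenyl does not always bring a large loss, and these two groups cannot be told apart here. No data at hand explain this swing.

On these data alone, it remains open whether the methyl ester itself matters, which a carboxylic acid or a primary amide in its place on the phenyl ring could test. As far as these compounds go, the plain unsubstituted phenyl group also remains open, as does a 4-chlorophenyl group.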